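Sulfonamide series: an aryl group replaces the amide

The source may hold more compounds than are shown below. What is called first, only, known or untested is meant among the compounds shown, and "the series" means these compounds.

Compound 1 `CNC(=O)c1cncc(NS(=O)(=O)c2cc(Cl)ccc2OC)c1`: 109 nM
Compound 2 `COC(=O)c1cncc(NS(=O)(=O)c2cc(Cl)ccc2OC)c1`: 65 nM
Compound 3 `CCNC(=O)c1cncc(NS(=O)(=O)c2cc(Cl)ccc2OC)c1`: 193 nM

Three compounds share a core and differ only in the group on the carbonyl carbon. In an assay on isolated protein for inhibition of alkaline phosphatase, tissue-nonspecific isozyme (Homo sapiens) (a lower number here means a stronger inhibitor, a higher number a weaker inhibitor), compound 3 gives 193 nM and stands with the highest number of the three. Its nearest neighbour is compound 1, and the step of a 1.8-fold higher number from compound 1 to compound 3 (0.25 log units; within the scatter) lies within the scatter. Against compound 2 the gap is wider: a 3.0-fold higher number from compound 2 to compound 3 (0.47 log units; beyond the scatter) is a modest step beyond the scatter. The step of a 1.7-fold lower number from compound 1 to compound 2 (0.22 log units; within the scatter) is itself within the scatter.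

Compound 4 `COc1ccc(Cl)cc1S(=O)(=O)Nc1cncc(-c2cccc(C)c2)c1` is not yet measured. It departs from compound 3 by 3-methylphenyl in place of ethylcarbamoyl on an aromatic carbon. Among the compounds with values here, none of the measured steps bears on this change directly: each of them alters only the substituent on the carbonyl carbon, while here the whole carbonyl-bearing group is removed and an aromatic ring enters in its place. The measured steps show that changes at this position have so far moved the number only modestly, and they give no direction for a replacement of this kind. Compound 4 is therefore expected to stay near compound 3, with a wide range in either direction, as the step of a 1.0-fold higher number from compound 3 to compound 4 (0.02 log units; within the scatter) is meant to express. The estimate for compound 4 in this assay is 200 nM, between 40 nM and 1500 nM.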

Compound 4, half-maximal inhibitory concentration: 160 nM
Compound 4: the middle estimate sits 1.3-fold (0.10 log units) above what was measured; the measured number falls inside the stated range.
By their numbers in this assay, from the lowest: compounds 2, 1, 4 and 3 (each within the scatter of the next, the first and the last beyond it).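

Until compound 4, every change had altered only the substituent on the carbonyl carbon; this result shows that the whole ethylcarbamoyl group can give way to 3-methylphenyl without a change beyond the scatter in this assay, as the step of a 1.2-fold lower number from compound 3 to compound 4 (0.08 log units; within the scatter) shows. The same holds against the methylcarbamoyl group, with a 1.5-fold higher number from compound 1 to compound 4 (0.17 log units; within the scatter), so in these two comparisons neither the carbonyl nor the amide hydrogen is needed to stay in this range, even though the entering group has 0 hydrogen-bond donors and 0 hydrogen-bond acceptors. Only methoxycarbonyl stands apart, with a 2.5-fold higher number from compound 2 to compound 4 (0.39 log units; beyond the scatter), a modest step beyond the scatter, and no measurement offered here accounts for any of these steps.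

The compounds shown leave open how much of the value of compound 4 depends on its methyl group, and how a plain phenyl group would compare on this aromatic carbon. They also leave open how a carboxylic acid or a primary amine would behave in the same place on the shared core.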